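Removing the Ring Hydroxy: From Compound 3 to Compound 4

The source may hold more compounds than are shown below. What is called first, only, known or untested is meant among the compounds shown, and "the series" means these compounds.

Of the compounds shown here, three have been measured in a physicochemical assay for lipophilicity, at pH 7.4; on this read-out lower numbers stand for lower lipophilicity and higher numbers for higher lipophilicity. Compound 1 `N#Cc1cccc(NC(=O)c2cc(C(F)(F)F)ccc2OCc2ccc(F)cc2)c1` gives 7.5. Compound 2 `O=C(Nc1ccnnc1)c1cc(N2CCC(CO)CC2)ccc1OCc1ccccc1` gives 3.5, and compound 3 `O=C(Nc1ccnnc1)c1cc(N2CCC(O)CC2)ccc1OCc1ccccc1` gives 3.2. Compound 3 stands at the lowest of the three numbers, yet its distance to compound 2 is within the scatter, so the two cannot be told apart; compound 1 lies far above both, well beyond the scatter.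

Among the measured compounds shown here, one measured step bears on the present question: a number 0.30 log units lower from compound 2 to compound 3 (within the scatter). Compound 4 `O=C(Nc1ccnnc1)c1cc(N2CCCCC2)ccc1OCc1ccccc1` has not been measured. It differs from compound 3 in one place: hydrogen in place of hydroxy on a saturated ring carbon. For the measured compounds named here, the only measured step that touches this ring group is the one from compound 2 to compound 3, and it stayed within the scatter. Taking the hydroxy away altogether goes further than swapping hydroxymethyl for hydroxy, and no measured pair shows that exact change. The expectation is nevertheless a rise beyond the scatter, estimated as a number 0.80 log units higher from compound 3 to compound 4 (beyond the scatter). Compound 4 is therefore expected to read 4 in this assay, with a likely range from 3.5 to 4.6.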

Compound 4, distribution coefficient: 6.3
For compound 4 the middle estimate is 2.30 log units below the measured one, outside the stated range (above it).
By their numbers in this assay, from the lowest: compounds 3 and 2 (each within the scatter of the next); then compound 4; then compound 1.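

In this assay, among the compounds shown here, this place on the ring proves far more responsive than the earlier compounds suggested: going from 4-hydroxypiperidin-1-yl to piperidin-1-yl gives a number 3.10 log units higher from compound 3 to compound 4 (beyond the scatter) on losing a single hydroxy group. Removing the hydroxymethyl group instead gives a number 2.80 log units higher from compound 2 to compound 4 (beyond the scatter) on the same saturated ring carbon, so the two changes point the same way. Compound 2 and compound 3 could not be told apart, and the swap between them hid what compound 4 now reveals: among these three compounds, what matters at this carbon is whether such a group is there at all, not which of the two it is.

Still open, going by these compounds, is where an amine, a carboxylic acid or a methoxy group on this ring carbon would fall, whether close to compound 3 or close to compound 4. Nothing available here accounts for the size of these steps.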